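This account rests on a few compounds, and the source may have more. Where it says the series, first, only, none or still open, it means among the compounds named here.

Measured compounds in this series:
compound 1 `CN(C(=O)NC(=O)c1ccc(Cl)cc1Cl)c1nc(C(F)(F)F)c(C(=O)N/N=C/c2cccc(C(F)(F)F)c2)s1`: 10.7 ug/mL
compound 2 `CN(C(=O)NC(=O)c1ccc(Cl)cc1Cl)c1nc(C(F)(F)F)c(C(=O)N/N=C/c2ccc(C(F)(F)F)cc2)s1`: 8.42 ug/mL
compound 3 `CN(C(=O)NC(=O)c1c(F)cccc1F)c1nc(C(F)(F)F)c(C(=O)N/N=C/c2cccc(C(F)(F)F)c2)s1`: 21.8 ug/mL

In a functional assay on MCF7 cells (Homo sapiens) for inhibition, read by MTT assay, with a stated time of 72 h (on this read-out higher numbers stand for weaker inhibition and lower numbers for stronger inhibition), compound 1 gives 10.7 ug/mL, the second highest of the three numbers. Its nearest neighbour is compound 2, with a 1.3-fold lower number from compound 1 to compound 2 (0.10 log units; within the scatter), a change confined to the aryl ring attached to the carbon with the double bond to nitrogen. The furthest is compound 3, with a 2.0-fold higher number from compound 1 to compound 3 (0.31 log units; beyond the scatter), a change on the other aryl ring, the one on the carbonyl carbon.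

Compound 4 `CN(C(=O)NC(=O)c1ccc(Cl)cc1Cl)c1nc(C(F)(F)F)c(C(=O)N/N=C/c2cc(C(F)(F)F)cc(C(F)(F)F)c2)s1` differs from compound 1 in one place: trifluoromethyl in place of hydrogen on an aromatic carbon. Among the measured compounds shown here, the step that bears most directly on it is the one from compound 1 to compound 2, since it alters the same ring and stays within the scatter. The step from compound 1 to compound 3 touches a different part of the molecule and is only a modest move. On this basis no step beyond the scatter is expected in this assay for compound 4, in either direction.

The estimate for compound 4 in this assay is 9.5 ug/mL, between 4.5 ug/mL and 20 ug/mL. This means an expected step of a 1.1-fold lower number from compound 1 to compound 4 (0.05 log units; within the scatter).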

Compound 4, half-maximal inhibitory concentration: > 100 ug/mL
Compound 4 was reported as a limit (the forecaster's own chance of this, stated with the estimate: 5%); middle value at least 10-fold (1.02 log units) from the limit.
By their numbers in this assay, from the lowest: compounds 2 and 1 (each within the scatter of the next); then compound 3. At a limit, above all of these: compound 4.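

In this assay, trifluoromethyl in place of hydrogen on this aromatic carbon, meta to a trifluoromethyl group, gives an at least 9.3-fold higher number from compound 1 to compound 4 (0.97 log units; beyond the scatter), the largest step among the compounds shown. Moving the single trifluoromethyl on the same ring gave only a 1.3-fold lower number from compound 1 to compound 2 (0.10 log units; within the scatter), so this ring accepted that shift, whereas the added trifluoromethyl weakens inhibition well beyond the scatter. The value of compound 4, > 100 ug/mL, is a limit and not a number: the limit of > 100 ug/mL in this assay, at which 1 of the 4 values shown sits.

The compounds shown cannot separate the effect of this position from that of carrying two trifluoromethyl groups, and they hold no other group on this carbon, such as a methyl, a methoxy or an amine. Going by these compounds, it also stays open whether the added trifluoromethyl would give a similar step with the 2,6-difluorophenyl of compound 3.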